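The source may report more compounds than this note shows. Statements on the series, on what has been measured and on what is new or still open speak of the compounds shown alone.

Compound 1 `COc1ccc(S(=O)(=O)N2CCc3cccc(NC(=O)c4ccc([N+](=O)[O-])cc4)c32)cc1`: 95 nM in a functional assay on KB cells (Homo sapiens) for cytotoxicity; on this read-out lower numbers stand for stronger inhibition and higher numbers for weaker inhibition
Compound 2 `COc1ccc(S(=O)(=O)N2CCc3cccc(NCc4ccccc4)c32)cc1`: > 10000 nM in this assay

In this assay compound 2 stands at the limit of > 10000 nM in this assay, at which 1 of the 2 values shown sits, so only a limit and no number is known for it. Compound 3 `COc1ccc(S(=O)(=O)N2CCc3cccc(NC(=O)c4ccco4)c32)cc1` differs from compound 2 in a single place: (furan-2-yl)carbonyl in place of benzyl on a nitrogen on an aromatic ring. The step from compound 2 to compound 3 is expected to be large and towards stronger inhibition, an at least 25-fold lower number from compound 2 to compound 3 (1.39 log units; beyond the scatter), because compound 1, which likewise carries a carbonyl group in place of the benzyl, gives 95 nM in this assay. Compound 3 is therefore estimated at 400 nM, within a range of 80 nM to 3000 nM.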

Compound 3, half-maximal inhibitory concentration: 9.2 nM
Beside the measured number, compound 3's estimate is 43-fold (1.64 log units) above it, outside the stated range (below it).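

For compound 2 the value is only a limit, not a number: the limit of > 10000 nM in this assay, at which 1 of the 3 values shown sits.

Even so, (furan-2-yl)carbonyl in place of benzyl on this nitrogen gives an at least 1000-fold lower number from compound 2 to compound 3 (3.03 log units; beyond the scatter), so in this assay the carbonyl series reaches far stronger inhibition. The carbonyl alone does not set the value, since furan-2-yl in place of 4-nitrophenyl on the carbonyl carbon gives a 10-fold lower number from compound 1 to compound 3 (1.01 log units; beyond the scatter).

On these data alone, it remains open how a plain phenyl, a thiophene ring or a small methyl on the carbonyl carbon would compare. The compounds shown also cannot separate the role of the furan ring from the loss of the nitro group.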